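Methoxy to trifluoromethyl: what it did to solubility

A few compounds are considered here, and "the series" means these few. Any claim that something is new, unique, unknown or untested is made for them only; others in the source may bear on it.

Compound 1 `CCOC(=O)c1c(-c2ccc(C(F)(F)F)cc2)[nH]c2cccc(OC)c2c1=O` gives in a physicochemical assay for solubility, in phosphate buffer, at pH 7.4 (a higher number here means a more soluble compound, a lower number a less soluble compound), a value of 22000 nM.
Compound 2 `CCOC(=O)c1c(-c2ccc(OC)cc2)[nH]c2cccc(OC)c2c1=O` gives in this assay only a limit, > 100000 nM.
Compound 3 `CCOC(=O)c1c(-c2cccc(OC)c2)[nH]c2cc(OC)ccc2c1=O` gives in this assay only a limit, > 100000 nM.

Compound 2 and compound 1 differ in one place, (trifluoromethyl in place of methoxy on an aromatic carbon). That change brought an at least 4.5-fold lower number from compound 2 to compound 1 (0.65 log units; beyond the scatter). The true size of this step is known only as a bound, because compound 2 sits at the limit of > 100000 nM in this assay, at which 2 of the 3 values shown sit.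

Compound 3 is built from the same atoms as compound 2, joined differently; the difference between the two cores is not broken down here. Compound 4 `CCOC(=O)c1c(-c2cccc(C(F)(F)F)c2)[nH]c2cc(OC)ccc2c1=O` has not yet been measured in this assay. It differs from compound 3 by trifluoromethyl in place of methoxy on an aromatic carbon. Going by the values given here, this is the same kind of change as the one from compound 2 to compound 1, not the same: in compound 4 the new group sits meta to a large group, whereas in compound 1 it sits para to a large group.

A step of at least the size seen earlier is expected, namely an at least 4.0-fold lower number from compound 3 to compound 4 (0.60 log units; beyond the scatter), resting on the measured step of an at least 4.5-fold lower number from compound 2 to compound 1 (0.65 log units; beyond the scatter). Compound 3 itself starts at a limit, > 100000 nM, so the starting point is not a number. Compound 4 is therefore estimated at about 25000 nM, most likely between 8000 nM and 100000 nM.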

Compound 4, solubility: 19000 nM
Beside the measured number, compound 4's estimate is 1.3-fold (0.12 log units) above it; the measured number falls inside the stated range.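

In this assay, putting trifluoromethyl in place of methoxy again brought a change beyond the usual scatter, an at least 5.2-fold lower number from compound 3 to compound 4 (0.72 log units; beyond the scatter), and it runs the same way as the earlier step, an at least 4.5-fold lower number from compound 2 to compound 1 (0.65 log units; beyond the scatter). The change therefore carried from one core to the other with the same direction of effect, even though in compound 4 the new group sits meta to a large group. This rests on only two pairs of compounds, so it shows no general rule for the series, and the size of the two steps cannot be compared, nor can it be said that the two cores respond equally, because compound 2 and compound 3 each start from a limit rather than a number: the limit of > 100000 nM in this assay, at which 2 of the 4 values shown sit.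

The compounds shown carry only methoxy or trifluoromethyl at the changed place, so what an amine, a carboxylic acid or a longer chain such as butoxy would do there in this assay remains open. Also open, as far as these compounds go, is how large the step would be from a starting compound with a true number, and whether the ethyl ester shared by all four compounds plays any part in these values.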